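The source may hold more compounds than are shown below. What is called first, only, known or untested is meant among the compounds shown, and "the series" means these compounds.

Compound 1 `Cc1ccc(CS/C(=C/c2ccc(C)s2)C(=O)c2ccc(Cl)cc2)cc1` is inactive on the numbers at hand: in a functional assay on DU-145 cells (Homo sapiens) for inhibition, read by trypan blue exclusion, with a stated time of 96 h (on this read-out higher numbers stand for weaker inhibition of growth and lower numbers for stronger inhibition of growth), compound 1 gives 50000 nM. Among the measured compounds shown here, its only measured neighbour is compound 2 `Cc1ccc(CS/C(=C/c2ccc(O)c(O)c2O)C(=O)c2ccc(Cl)cc2)cc1`, which in this assay gives 50000 nM, so the step of no change at the digits printed from compound 1 to compound 2 (within the scatter) is flat. For the measured compounds named here, compound 3 `Cc1ccc(/C=C(/SCc2ccc(F)cc2)C(=O)c2ccc(Cl)cc2)s1` differs from compound 1 by fluoro in place of methyl on an aromatic carbon, a change at a site for which no step has been measured. Going by the values given here, the flat step from compound 1 to compound 2 is the only guide, and it suggests that the core tolerates exchanges without visible effect. Compound 3 is therefore expected to match compound 1, with the expected step of no change at the digits printed from compound 1 to compound 3 (within the scatter) and an estimated value of 50000 nM (range 20000 nM to 50000 nM).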

Compound 3, concentration for 50% growth inhibition: > 100000 nM
Compound 3: no number, only a limit (the forecaster's own chance of this, stated with the estimate: 60%); middle value at least 2.0-fold (0.30 log units) away from the limit.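

Among the compounds shown here, this position on the benzyl group had no measured step before, and fluoro in place of methyl on an aromatic carbon now gives an at least 2.0-fold higher number from compound 1 to compound 3 (0.30 log units; that floor lies within the scatter) in this assay. For compound 3 the reading is a limit and not a number: the limit of > 100000 nM in this assay, at which 1 of the 3 values shown sits. As far as these compounds go, the 4-fluorobenzyl group therefore shows no stronger inhibition of growth than the 4-methylbenzyl group, and the true size of the step stays unknown.

Open, from the compounds shown here alone, is what a methoxy group, an amine or a carboxylic acid at this position would give. Also open, going by these compounds, is whether any change to the shared core gives a clearly lower number.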